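The compounds below may be only part of what the source reports. "The series", "measured", "known", "first", "only" and "open" are said of these compounds alone.

Measured so far:
- compound 1, `Cc1cc(C)c(NC(=O)N(Cc2cccc(-c3nn[nH]n3)c2)C2CCCCCC2)c(C)c1`: > 1000 nM
- compound 2, `Cc1cc(C)c(NC(=O)N(Cc2cccc(-n3cccc3)c2)C2CCCCCC2)c(C)c1`: 20 nM
- compound 3, `Cc1cc(C)c(NC(=O)N(Cc2ccc(-n3cccn3)cc2)C2CCCCCC2)c(C)c1`: 70 nM

In an assay on microsomes from intestine for inhibition of acyl-CoA:cholesterol acyltransferase (Oryctolagus cuniculus) (a lower number here means a stronger inhibitor, a higher number a weaker inhibitor), compound 1 gives only a limit, > 1000 nM, and no number; this is the limit of > 1000 nM in this assay, at which 1 of the 3 values shown sits. Compound 2 gives 20 nM in this assay. Among the compounds with values here, compound 3 gives 70 nM, the higher of the two numbers known, with compound 2 as its nearest neighbour on a lower number.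

Within the data shown here, the only single-point step measured is an at least 50-fold lower number from compound 1 to compound 2 (1.69 log units; beyond the scatter), where the five-membered aromatic ring bearing more ring nitrogens sits on the side of the limit and the all-carbon ring on the side of the low number.

Compound 4, `Cc1cc(C)c(NC(=O)N(Cc2ccc(-n3nccn3)cc2)C2CCCCCC2)c(C)c1`, is to be measured. It differs from compound 3 by 2H-1,2,3-triazol-2-yl in place of 1H-pyrazol-1-yl on an aromatic carbon. The change is of the same kind as the measured step, an added ring nitrogen, but far smaller than the swap from tetrazolyl to pyrrolyl, so a modest rise in the number is expected rather than a large one.

The step from compound 3 to compound 4 is expected to be a 2.1-fold higher number from compound 3 to compound 4 (0.33 log units; beyond the scatter). For compound 4 the estimate is 150 nM, in the range 50 nM to 500 nM.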

Compound 4, half-maximal inhibitory concentration: 130 nM
Compound 4: middle estimate off by 1.2-fold (0.06 log units), on the high side; the measured number falls inside the stated range.
By their numbers in this assay, from the lowest: compound 2; then compounds 3 and 4 (each within the scatter of the next). At a limit, above all of these: compound 1.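

At the place on an aromatic carbon of a six-membered aromatic ring of carbon only, para to a large group, 2H-1,2,3-triazol-2-yl in place of 1H-pyrazol-1-yl gives a 1.9-fold higher number from compound 3 to compound 4 (0.27 log units; within the scatter) in this assay as the step. The earlier compounds shown here offered no swap confined to a single added ring nitrogen; here, that swap leaves the two values indistinguishable, so this place accepts either neutral five-membered aromatic ring. No measurement shown here bears on why the two rings read alike.

As far as these compounds go, whether the same swap reads alike with the ring placed as in compound 2 remains open. Also open, from the compounds shown here alone, is how a carboxylic acid or a dimethylamino group at this place would compare with the two rings.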